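Adding a Methoxy Group to a Chalcone-Like Pyrazole Series

The source may hold more compounds than are shown below. What is called first, only, known or untested is meant among the compounds shown, and "the series" means these compounds.

Measured compounds:
compound 1 `COc1ccc(-c2cc(/C=C/C(=O)c3ccc(N)cc3)[nH]n2)cc1`, -86%
compound 2 `COc1ccc(C(=O)/C=C/c2cc(-c3cc(OC)c(OC)c(OC)c3)n[nH]2)cc1OC`, -93%
compound 3 `COc1ccc(-c2cc(/C=C/C(=O)c3ccc(N)cc3)[nH]n2)cc1OC`, -79%

All three were tested in a functional assay on COLO 205 cells (Homo sapiens) for cytotoxicity, read by sulforhodamine B assay, with a stated time of 48 h, tested at 10 uM; a higher number here means a weaker effect of the compound at the concentration tested, a lower number a stronger effect. Compound 1 gives -86%, and compound 3 gives -79%; the change between them is methoxy in place of hydrogen on an aromatic carbon, and the step of a number 7 percentage points higher from compound 1 to compound 3 (within the scatter). Compound 2 differs from compound 1 in more than one place, and the difference between the two cores is not broken down here; in this assay compound 2 gives -93%.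

Compound 4 `COc1cc(C(=O)/C=C/c2cc(-c3cc(OC)c(OC)c(OC)c3)n[nH]2)cc(OC)c1OC` has not been measured. It differs from compound 2 by methoxy in place of hydrogen on an aromatic carbon. The place is not identical to that of the change from compound 1 to compound 3: here the entering group is also meta to a methoxy group, so this is the same kind of change rather than the same one.

Because a number 7 percentage points higher from compound 1 to compound 3 (within the scatter), a step of similar size is expected here as well, namely a number 5 percentage points higher from compound 2 to compound 4 (within the scatter). For compound 4 in this assay the estimated value is -88%, expected to lie between -100% and -72%.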

Compound 4, a percentage reported as activity, at one concentration (the size of the read-out at that concentration, not a potency): -100%
Compound 4: the middle estimate sits 12 percentage points above what was measured; the measured number falls inside the stated range.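

On the core of compound 2, putting methoxy in place of hydrogen on an aromatic carbon gives, in this assay, a number 7 percentage points lower from compound 2 to compound 4 (within the scatter). Set beside the same kind of change on the core of compound 1, this step cannot be told apart from the earlier one: the same change on two cores in this assay, a number 7 percentage points higher (within the scatter) from compound 1 to compound 3 and a number 7 percentage points lower (within the scatter) from compound 2 to compound 4, 14 percentage points apart, within the scatter of two such steps So on both cores the change stays within the scatter, and nothing here suggests that the core alters its outcome, but two pairs in a single cell assay do not prove that the added methoxy group is without effect or that a third core would behave alike.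

The compounds shown leave open what other groups at this place would do, such as a hydroxyl group, a chlorine atom or a longer chain like ethoxy. Also open is how the effects of these compounds compare at other concentrations, for the read-out gives only the size of the effect at one concentration.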